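Chloro replaces hydroxymethyl on a pyrazole acid scaffold

The compounds below may be only part of what the source reports. "The series", "measured", "known", "first", "only" and "open" are said of these compounds alone.

Measured compounds:
compound 1, `O=C(O)c1ccn(Cc2cc(Br)ccc2OCc2ccccc2)n1`, 55 nM
compound 2, `O=C(O)c1nn(Cc2cc(Br)ccc2OCc2ccccc2)cc1CO`, < 2000 nM

Compound 1, `O=C(O)c1ccn(Cc2cc(Br)ccc2OCc2ccccc2)n1`, carries a hydrogen on the five-membered ring and in a functional assay on CHO-K1 cells for antagonist activity at prostaglandin E2 receptor EP1 subtype (Homo sapiens), read by FLIPR (on this read-out lower numbers stand for stronger inhibition and higher numbers for weaker inhibition), compound 1 gives 55 nM. Compound 2, `O=C(O)c1nn(Cc2cc(Br)ccc2OCc2ccccc2)cc1CO`, bears a hydroxymethyl there instead, and for compound 2 the assay reports only a limit, < 2000 nM; this is the limit of < 2000 nM in this assay, at which 1 of the 2 values shown sits, so the true value of compound 2 is not fixed by the numbers shown. The step that the limit leaves unreadable from compound 1 to compound 2 is therefore unreadable.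

Compound 3, `O=C(O)c1nn(Cc2cc(Br)ccc2OCc2ccccc2)cc1Cl`, differs from compound 2 by one change, (chloro in place of hydroxymethyl on an aromatic carbon). Among the measured compounds shown here, no measured step covers a chloro at this position, and the only step touching this carbon, from compound 1 to compound 2, gives no size. Compound 1 with hydrogen is the nearest anchor. The change from compound 2 to compound 3 is expected to be a step that the limit leaves unreadable from compound 2 to compound 3, with wide uncertainty. Compound 3 is estimated at 100 nM, in the range 20 nM to 600 nM.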

Compound 3, inhibition constant: < 2000 nM
Compound 3: only a limit was reported (the forecaster's own chance of this, stated with the estimate: 20%); the middle value lies beyond the limit too.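

For compound 3, this assay gives only a limit, < 2000 nM, so no step from compound 1 or compound 2 to compound 3 can be read: the limit of < 2000 nM in this assay, at which 2 of the 3 values shown sit.

The compounds shown leave open how the hydroxymethyl of compound 2 and the chloro of compound 3 truly compare with each other and with the hydrogen of compound 1.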